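The source may report more compounds than this note shows. Statements on the series, on what has been measured and on what is new or still open speak of the compounds shown alone.

Compound 3 `Cn1c(=O)cnn(CCCCN2CCN(c3ccccc3)CC2)c1=O` carries a plain phenyl on the ring amine nitrogen and, in an assay for displacement of a labelled ligand from Adrenergic receptor alpha-1 (Homo sapiens) (on this read-out lower numbers stand for stronger inhibition and higher numbers for weaker inhibition), compound 3 gives 64 nM, the highest number of the three measured. Compound 1 `CCOc1ccccc1N1CCN(CCCCn2ncc(=O)n(C)c2=O)CC1` gives 1.8 nM and compound 2 `CSc1ccccc1N1CCN(CCCCn2ncc(=O)n(C)c2=O)CC1` gives 1.8 nM; the step of no change at the digits printed from compound 1 to compound 2 (within the scatter) shows the two substituted analogues as indistinguishable here. The steps of a 36-fold higher number from compound 1 to compound 3 (1.55 log units; beyond the scatter) and a 36-fold higher number from compound 2 to compound 3 (1.55 log units; beyond the scatter) show that stripping the aromatic substituent back to hydrogen costs a great deal.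

Compound 4 `Cn1c(=O)cnn(CCCCN2CCN(c3c(Br)cccc3C#N)CC2)c1=O` differs from compound 3 as 2-bromo-6-cyanophenyl in place of phenyl on an amine nitrogen in a ring. Within the data shown here, no measured step covers a bromine or a nitrile on that ring, so the bearing evidence is indirect: both measured substituted phenyls sit far below compound 3, and compound 4 restores substitution to that ring, now at two positions. A return toward the substituted compounds is therefore expected, though not necessarily the full span, since the groups differ from ethoxy and methylsulfanyl. For compound 4 the expected step is an 11-fold lower number from compound 3 to compound 4 (1.03 log units; beyond the scatter), a lower number. Compound 4 is estimated at 6 nM, within 1.5 nM to 30 nM.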

Compound 4, inhibition constant: 450 nM
For compound 4 the middle estimate is 75-fold (1.88 log units) below the measured one, outside the stated range (above it).
By their numbers in this assay, from the lowest: compounds 1 and 2 (each within the scatter of the next); then compound 3; then compound 4.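

Putting groups on the aromatic ring does not by itself bring the number down in this assay: 2-bromo-6-cyanophenyl in place of phenyl moves the read-out upward (a 7.0-fold higher number from compound 3 to compound 4 (0.85 log units; beyond the scatter)), the opposite direction to the 2-ethoxyphenyl of compound 1 and the 2-(methylsulfanyl)phenyl of compound 2. The gap to those two analogues is much wider (a 250-fold higher number from compound 2 to compound 4 (2.40 log units; beyond the scatter); a 250-fold higher number from compound 1 to compound 4 (2.40 log units; beyond the scatter)), so among these four compounds the identity of the substituents matters, not merely their presence. Nothing available here bears on the cause of this reversal.

Bromine and the nitrile enter together in compound 4, so their separate contributions remain unresolved. On these data alone, it also remains open whether 2-bromophenyl or 2-cyanophenyl alone would fall nearer compound 3 or nearer compounds 1 and 2.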